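Swapping methoxymethoxy for 2-hydroxyethoxy in compound 3

The source may report more compounds than this note shows. Statements on the series, on what has been measured and on what is new or still open speak of the compounds shown alone.

In an ADME assay (a higher number here means that the compound lasts longer, a lower number that the compound disappears faster), compound 3, `COCOc1cc(OC)ccc1C[S+]([O-])c1ncccc1C(=O)Nc1ccncc1`, gives the highest number at 8.25 h, ahead of compound 2, `COc1ccc(C[S+]([O-])c2ncccc2C(=O)Nc2ccncc2)c(OCCF)c1`, at 3.3 h, and compound 1, `CCOc1cc(OC)ccc1C[S+]([O-])c1ncccc1C(=O)Nc1ccncc1`, at 0.71 h. Compound 4, `COc1ccc(C[S+]([O-])c2ncccc2C(=O)Nc2ccncc2)c(OCCO)c1`, has the same atoms as compound 3, joined differently: hydroxymethyl in place of methoxy on a saturated chain carbon bound to an oxygen on an aromatic ring. The closest measured change also concerns that methoxy, and it gives a modest step, a 2.5-fold higher number from compound 2 to compound 3 (0.40 log units; beyond the scatter). The other steps, a 4.6-fold higher number from compound 1 to compound 2 (0.67 log units; beyond the scatter) and a 12-fold higher number from compound 1 to compound 3 (1.07 log units; beyond the scatter), show that changes at this chain can be modest or large. Read backwards, the closest change suggests a modest fall, so the expected step is a 2.8-fold lower number from compound 3 to compound 4 (0.44 log units; beyond the scatter). Compound 4 is estimated at 3 h, with an expected range of 1 h to 8 h.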

Compound 4, half-life: 1.78 h
Compound 4: the middle estimate sits 1.7-fold (0.23 log units) above what was measured; the range from low to high includes it.
By their numbers in this assay, from the lowest: compound 1; then compounds 4 and 2 (each within the scatter of the next); then compound 3.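

In this assay, the same atoms joined differently do not behave alike: the swap of methoxymethoxy for 2-hydroxyethoxy gives a 4.6-fold lower number from compound 3 to compound 4 (0.67 log units; beyond the scatter) and shows that atom content alone does not set the number. Two bonds along the chain from the oxygen on the aromatic ring, hydroxy in place of fluoro gives a 1.9-fold lower number from compound 2 to compound 4 (0.27 log units; within the scatter) and hydroxy in place of hydrogen gives a 2.5-fold higher number from compound 1 to compound 4 (0.40 log units; beyond the scatter) as its step. Nothing measured here accounts for these steps. Still open, going by these compounds, is how an amine or a carboxylic acid in place of the hydroxy, or a longer chain carrying it, would compare.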